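Sulfonate series: methylsulfonyl to dimethylamino on the benzoyl ring

The source may report more compounds than this note shows. Statements on the series, on what has been measured and on what is new or still open speak of the compounds shown alone.

Measured so far:
compound 1, `CN(C)c1ccc(C(=O)N2CCC(n3cncc3-c3ccc(OS(=O)(=O)c4cccc(C#N)c4)cc3)CC2)cc1`, 32 nM
compound 2, `CNC(=O)c1cccc(S(=O)(=O)Oc2ccc(-c3cncn3C3CCN(C(=O)c4ccc(S(C)(=O)=O)cc4)CC3)cc2)c1`, 202 nM

In an assay on HEK293 cells for antagonist activity at P2X purinoceptor 7 (Homo sapiens), read by fluorescence, with a stated time of 2 h (on this read-out higher numbers stand for weaker inhibition and lower numbers for stronger inhibition), compound 2 gives 202 nM, the higher of the two numbers recorded. Compound 1, which carries a different sulfonate ester as well as a different group on the benzoyl ring, gives 32 nM in this assay, and the gap between the two lies beyond the usual scatter. Since compound 1 and compound 2 differ in two places, no single step can be read from them.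

Compound 3, `CNC(=O)c1cccc(S(=O)(=O)Oc2ccc(-c3cncn3C3CCN(C(=O)c4ccc(N(C)C)cc4)CC3)cc2)c1`, keeps the sulfonate ester of compound 2 and changes only the benzoyl substituent: dimethylamino in place of methylsulfonyl on an aromatic carbon. Within the data shown here, no measured pair shows this change on its own. Among the measured compounds shown here, the only guide is that compound 1, which bears the dimethylamino group, gives 32 nM, so a step toward lower numbers is expected for a 2.5-fold lower number from compound 2 to compound 3 (0.40 log units; beyond the scatter), though its size is uncertain. Compound 3 is estimated at 80 nM in this assay, within a range of 25 nM to 250 nM.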

Compound 3, half-maximal inhibitory concentration: 25 nM
Estimate against measurement, compound 3: 3.2-fold (0.51 log units) above; measured number inside the range.
By their numbers in this assay, from the lowest: compounds 3 and 1 (each within the scatter of the next); then compound 2.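

In this assay the benzoyl substituent now stands as a single change: dimethylamino in place of methylsulfonyl gives an 8.1-fold lower number from compound 2 to compound 3 (0.91 log units; beyond the scatter) with the sulfonate ester held fixed. The other single change, methylcarbamoyl in place of cyano on an aromatic carbon of the sulfonate ester, gives a 1.3-fold lower number from compound 1 to compound 3 (0.11 log units; within the scatter) with dimethylamino held fixed, so that ester change is not resolved in this assay. Of these two places, only the benzoyl substituent shifts the number beyond the scatter in the steps shown.

Nothing measured here accounts for the size of the benzoyl step. Open, going by these compounds, are how a cyclic amine such as morpholine or a carboxylic acid would read at this benzoyl position, and whether the ester change stays within the scatter with methylsulfonyl on the benzoyl ring.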